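The source may report more compounds than this note shows. Statements on the series, on what has been measured and on what is new or still open speak of the compounds shown alone.

Two compounds have been measured so far in a functional assay on the whole organism with Ovis aries as the target, read by hemolysis (on this read-out higher numbers stand for weaker inhibition and lower numbers for stronger inhibition), and are shown here:

Compound 1 `COc1cccc(-c2nn[nH]n2)c1` gives 1560000 nM
Compound 2 `CCOc1cccc(-c2nn[nH]n2)c1` gives 631000 nM

Among the measured compounds shown here, compound 2 holds the lower of these two numbers, and compound 1 is its only neighbour, higher by a margin beyond the scatter. Compound 3 `c1ccc(Oc2cccc(-c3nn[nH]n3)c2)cc1` is still unmeasured. It has phenyl in place of ethyl on an oxygen on an aromatic ring. For the measured compounds named here, only one measured step bears on this change: a 2.5-fold lower number from compound 1 to compound 2 (0.39 log units; beyond the scatter) with methyl in place of hydrogen on a saturated chain carbon bound to an oxygen on an aromatic ring. Going by the values given here, that step was modest and concerns the same oxygen, but no measured compound carries a ring there, so the guide is a loose one. In this assay another modest move toward a lower number is therefore expected, possibly somewhat larger than the last. The expected change is a 2.9-fold lower number from compound 2 to compound 3 (0.46 log units; beyond the scatter) on this estimate. For compound 3 the estimated value is 220000 nM with an expected range from 60000 nM to 700000 nM in this read-out.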

Compound 3, half-maximal inhibitory concentration: 798000 nM
Compound 3: the middle estimate sits 3.6-fold (0.56 log units) below what was measured; the whole stated range lies below it.
By their numbers in this assay, from the lowest: compounds 2, 3 and 1 (each within the scatter of the next, the first and the last beyond it).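

In this assay, the step of a 1.3-fold higher number from compound 2 to compound 3 (0.10 log units; within the scatter) shows that this oxygen on an aromatic ring carries phenyl in place of ethyl with no change that stands out from the scatter, even though phenyl brings a six-membered aromatic ring where ethyl has none. The step of a 2.0-fold lower number from compound 1 to compound 3 (0.29 log units; within the scatter) also stays within the scatter, so phenyl cannot be told apart from either methyl or ethyl here, although the step of a 2.5-fold lower number from compound 1 to compound 2 (0.39 log units; beyond the scatter) does separate those two, and the lower number that came with the added methyl therefore finds no continuation in the ring. Nothing at hand gives a measured reason for this result.

On these data alone, what stays open is whether a longer chain such as propyl or butyl on the same oxygen would follow ethyl or fall in with phenyl, and whether benzyl, which sets a ring further out on a saturated carbon, would behave like either of them. As far as these compounds go, it is equally open whether a chlorine, an amine or a carboxylic acid on the phenyl ring would shift the number in this assay at all.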